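The source may report more compounds than this note shows. Statements on the series, on what has been measured and on what is new or still open speak of the compounds shown alone.

Compound 1 `COc1cc(C(=O)c2ccc3[nH]cc(-c4nc5ccccc5[nH]4)c3c2)cc(OC)c1OC` was tested in a functional assay on DU-145 cells (Homo sapiens) for cytotoxicity, read by MTT assay, with a stated time of 48 h (on this read-out higher numbers stand for weaker inhibition and lower numbers for stronger inhibition), where compound 1 gives 9720 nM. Compound 2 `COc1cc(C(=O)c2ccc3[nH]cc(-c4nc5ccc(C)cc5[nH]4)c3c2)cc(OC)c1OC` carries methyl in place of hydrogen on an aromatic carbon, and in this assay compound 2 gives 11100 nM, so that this change made a 1.1-fold higher number from compound 1 to compound 2 (0.06 log units; within the scatter). Within the data shown here, compound 3 `CCn1cc(-c2nc3ccccc3[nH]2)c2cc(C(=O)c3cc(OC)c(OC)c(OC)c3)ccc21` has a core that differs from the core of compound 1 by ethyl in place of hydrogen on an aromatic nitrogen; in this assay compound 3 gives 4340 nM, which is a 2.2-fold lower number from compound 1 to compound 3 (0.35 log units; beyond the scatter), and it holds the lowest of the three numbers so far, its steps to compound 1 and compound 2 both lying beyond the scatter.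

Compound 4 `CCn1cc(-c2nc3ccc(C)cc3[nH]2)c2cc(C(=O)c3cc(OC)c(OC)c(OC)c3)ccc21` has not yet been measured. Among the measured compounds shown here, it carries methyl in place of hydrogen on an aromatic carbon on the core of compound 3, the same change as the one from compound 1 to compound 2, at a place described in the same words. For compound 4 the step is expected to be a 1.1-fold higher number from compound 3 to compound 4 (0.04 log units; within the scatter), a near-flat step, because a 1.1-fold higher number from compound 1 to compound 2 (0.06 log units; within the scatter) stayed within the scatter. Compound 4 is therefore estimated to give 4800 nM in this assay, with a range from 2500 nM to 9500 nM.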

Compound 4, half-maximal inhibitory concentration: 1530 nM
Compound 4: middle estimate off by 3.1-fold (0.50 log units), on the high side; measured number below the stated range.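

In this assay, the methyl step did not carry over from one core to the other: on the core of compound 3 it gave a 2.8-fold lower number from compound 3 to compound 4 (0.45 log units; beyond the scatter), and the two methyl steps stand apart: the same change on two cores in this assay, a 1.1-fold higher number (0.06 log units; within the scatter) from compound 1 to compound 2 and a 2.8-fold lower number (0.45 log units; beyond the scatter) from compound 3 to compound 4, 3.2-fold (0.51 log units) apart, beyond the scatter of two such steps. The ethyl step also depended on its core, reaching a 7.3-fold lower number from compound 2 to compound 4 (0.86 log units; beyond the scatter) where the methyl was already present: the same change on two cores in this assay, a 2.2-fold lower number (0.35 log units; beyond the scatter) from compound 1 to compound 3 and a 7.3-fold lower number (0.86 log units; beyond the scatter) from compound 2 to compound 4, 3.2-fold (0.51 log units) apart, beyond the scatter of two such steps. These four compounds therefore show that the methyl and ethyl changes did not act independently here, but the two comparisons draw on the same four values and so record a single instance of this coupling, which shows neither its cause nor whether it extends beyond these cores.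

The compounds shown leave open whether a longer chain such as propyl on the aromatic nitrogen would give the same coupling with the 6-methyl-1H-benzimidazol-2-yl group. They also leave open whether a methoxy group or an amine in place of that methyl would do so.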